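Methoxy to hydroxy on compound 2

The compounds below may be only part of what the source reports. "The series", "measured", "known", "first", "only" and "open" are said of these compounds alone.

In a functional assay on LNCaP cells (Homo sapiens) for antiproliferative activity, read by luminescence, with a stated time of 96 h (a lower number here means a stronger inhibitor, a higher number a weaker inhibitor), compound 2 `COc1cc2c(cc1NS(=O)(=O)c1cc(Br)ccc1OC)OC(C)(C)C(=O)N2` gives 4410 nM and compound 1 `CC1(C)Oc2cc(NS(=O)(=O)C3CCCCC3)ccc2NC1=O` gives 8400 nM as its value. These two numbers lie within the usual scatter of each other, so neither compound can be ranked above the other.

Compound 3 `COc1ccc(Br)cc1S(=O)(=O)Nc1cc2c(cc1O)NC(=O)C(C)(C)O2` is compound 2 with a single change, hydrogen in place of methyl on an oxygen on an aromatic ring (hydrogen in place of methyl on an oxygen on an aromatic ring, methoxy to hydroxy). Going by the values given here, no measured pair shows this change, so the data do not fix its size or its direction. The expected outcome is no step beyond the scatter, with a 1.2-fold higher number from compound 2 to compound 3 (0.10 log units; within the scatter) as the estimated move and only a slight lean towards a higher number. Compound 3 is estimated at 5500 nM with an expected range of 1800 nM to 15000 nM in this assay once it is measured.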

Compound 3, half-maximal inhibitory concentration: 7700 nM
Compound 3: the middle estimate sits 1.4-fold (0.15 log units) below what was measured, and the stated range covers the measured number.
By their numbers in this assay, from the lowest: compounds 2, 3 and 1 (each within the scatter of the next).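

Going by these compounds alone, this is the first measured pair for this change, and it gives a size for it: in this assay methoxy to hydroxy on the aromatic ring amounts to a 1.7-fold higher number from compound 2 to compound 3 (0.24 log units; within the scatter). Removing the methyl from that oxygen therefore leaves no readable shift in this pair, and compound 2 and compound 3 cannot be ranked against each other. One pair at one position says nothing about how the same change behaves on other compounds, and nothing measured here bears on the reason for the result.

From the compounds shown here alone, it remains open whether an amine or a longer chain such as ethoxy at this position would also stay within the scatter of compound 2. The same is true of replacing the methoxy that compound 3 keeps with hydroxy.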